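Amide series: ring change on the pyridine-borne amine

The source may hold more compounds than are shown below. What is called first, only, known or untested is meant among the compounds shown, and "the series" means these compounds.

Measured in a functional assay on CHO-K1 cells for antagonist activity at transient receptor potential cation channel subfamily V member 1 (Homo sapiens), read by FLIPR; a lower number here means a stronger inhibitor, a higher number a weaker inhibitor:
compound 1 `CC(C(=O)NCc1ccc(C(F)(F)F)nc1N1CCC(C)(C)CC1)c1ccc(NS(C)(=O)=O)c(F)c1` gives 0.3 nM
compound 2 `COC1CCN(c2nc(C(F)(F)F)ccc2CNC(=O)C(C)c2ccc(NS(C)(=O)=O)c(F)c2)CC1` gives 2.4 nM

Among the compounds with values here, compound 2 carries the higher of the two numbers in this assay; the only other compound, compound 1, lies an 8.0-fold higher number from compound 1 to compound 2 (0.90 log units; beyond the scatter) away, the sole step recorded so far, and it belongs to the swap of the 4,4-dimethylpiperidin-1-yl group for the 4-methoxypiperidin-1-yl group.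

Compound 3 `CC(C(=O)NCc1ccc(C(F)(F)F)nc1N1CCN(C)CC1)c1ccc(NS(C)(=O)=O)c(F)c1` is not yet measured. It differs from compound 2 in one place: 4-methylpiperazin-1-yl in place of 4-methoxypiperidin-1-yl on an aromatic carbon. Within the data shown here, no measured pair in the set has the 4-methylpiperazin-1-yl group, so no step bears directly on this change. Among the measured compounds shown here, the one known step, from compound 1 to compound 2, shows that the group on this aromatic carbon can move the number by a modest amount, and that is the only guide to the size of the change to expect.

On this basis compound 3 is expected to land near compound 2, with a step of a 2.1-fold higher number from compound 2 to compound 3 (0.32 log units; beyond the scatter) allowed for in either direction but most likely a small loss. The estimate for compound 3 in this assay is 5 nM, within a range of 1 nM to 25 nM.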

Compound 3, inhibition constant: 146 nM
Compound 3: middle estimate off by 29-fold (1.47 log units), on the low side; measured number outside the range, above it.
By their numbers in this assay, from the lowest: compound 1; then compound 2; then compound 3.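

In this assay, this position, on the aromatic carbon next to the ring nitrogen, proves far less forgiving than the first step suggested: a 61-fold higher number from compound 2 to compound 3 (1.78 log units; beyond the scatter) is much larger than an 8.0-fold higher number from compound 1 to compound 2 (0.90 log units; beyond the scatter), and the full span across the series is a 490-fold higher number from compound 1 to compound 3 (2.69 log units; beyond the scatter). The swap from 4-methoxypiperidin-1-yl to 4-methylpiperazin-1-yl leaves the counted hydrogen-bond donors and acceptors unchanged and alters the ring by one hetero atom, so those counts do not separate compound 2 from compound 3, even though the two groups are close in size and shape of ring. Nothing available here bears on the origin of this loss.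

The compounds shown leave open whether the loss follows the second ring nitrogen itself or the methyl group on it; a morpholin-4-yl group, a 4-methylpiperidin-1-yl group or a piperazin-1-yl group with an acetyl on that nitrogen, at the same carbon, would separate these readings. Also open, on these data alone, is whether the same order of the three groups holds on a core with a different group in place of the trifluoromethyl group, such as a nitrile.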